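The source may hold more compounds than are shown below. What is called first, only, known or untested is meant among the compounds shown, and "the series" means these compounds.

Measured so far:
Compound 1, `N#CC1=C(N)Oc2nc(Nc3ccc(S(N)(=O)=O)cc3)sc2C1c1ccc(Cl)cc1`: 39400 nM
Compound 2, `N#CC1=C(/N=C/c2ccc(Cl)cc2)Oc2nc(Nc3ccc(S(N)(=O)=O)cc3)sc2C1c1ccc(Cl)cc1`: 34600 nM

Both were tested in a functional assay on MCF7 cells (Homo sapiens) for antiproliferative activity, read by sulforhodamine B assay, with a stated time of 48 h; a lower number here means a stronger inhibitor, a higher number a weaker inhibitor. Compound 1 gives 39400 nM and compound 2 gives 34600 nM; the two numbers sit within the scatter of each other, so neither can be called the stronger inhibitor. For the measured compounds named here, the only measured step is a 1.1-fold lower number from compound 1 to compound 2 (0.06 log units; within the scatter), in which a group of 9 heavy atoms took the place of one nitrogen atom on a double-bonded ring carbon, with no effect beyond the scatter.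

Compound 3, `N#CC1=C(NC(N)=O)Oc2nc(Nc3ccc(S(N)(=O)=O)cc3)sc2C1c1ccc(Cl)cc1`, changes the same place again: a group of 4 heavy atoms (1 carbon, 2 nitrogen, 1 oxygen; no ring) in place of a group of 9 heavy atoms (7 carbon, 1 nitrogen, 1 chlorine; one six-membered aromatic ring of carbon only), on a double-bonded ring carbon. Going by the values given here, the only step that bears on this change is a 1.1-fold lower number from compound 1 to compound 2 (0.06 log units; within the scatter): exchanging the substituent at this position left the number where it was, and nothing in the data shows that the ureido would behave differently. The expected step is therefore a 1.0-fold higher number from compound 2 to compound 3 (0.00 log units; within the scatter), none beyond the scatter. Compound 3 is accordingly estimated at 35000 nM, with a range of 15000 nM to 90000 nM.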

Compound 3, half-maximal inhibitory concentration: 49800 nM
Beside the measured number, compound 3's estimate is 1.4-fold (0.15 log units) below it; low and high end bracket the measured number.
By their numbers in this assay, from the lowest: compounds 2, 1 and 3 (each within the scatter of the next).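

With the ureido group on the double-bonded ring carbon, both steps that reach compound 3 in this assay stay within the scatter: one from the ring-bearing group of compound 2 (a 1.4-fold higher number from compound 2 to compound 3 (0.16 log units; within the scatter)), the other where carbamoyl takes the place of hydrogen on the amine nitrogen (a 1.3-fold higher number from compound 1 to compound 3 (0.10 log units; within the scatter)). For the compounds shown here, the first pair showed only that a large group with a six-membered aromatic ring could not be told apart from the plain amine, whereas the ureido group has no ring and does have hydrogen-bond donors, yet compound 3 cannot be told apart from either of them. Three substituents that differ this much therefore give no measurable separation at this position, and no evidence here offers a reason for that.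

On these data alone, what stays open is whether any group at this position can move the number beyond the scatter, for example a carboxylic acid or a longer alkyl chain on the amine nitrogen. The compounds shown also leave untested how much the number depends on the cyano group or the 4-chlorophenyl group, since both stay the same throughout.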